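Rearranging a Bicyclic Amine in a Solubility Series

A few compounds are considered here, and "the series" means these few. Any claim that something is new, unique, unknown or untested is made for them only; others in the source may bear on it.

Compound 1, `COc1ccc2[nH]c(C(=O)N3CC(=O)N(Cc4ccccc4)[C@@H](CN4CCC5(CC4)CC5)C3)cc2c1`, was tested in a physicochemical assay for solubility, read by spectrophotometry, in phosphate buffer, with a stated time of 2 h, at pH 7.4 (a lower number here means a less soluble compound, a higher number a more soluble compound), and gives 28200 nM. Of the two compounds measured, compound 1 stands lowest; its nearest neighbour, compound 2, `COc1ccc2[nH]c(C(=O)N3CC(=O)N(Cc4ccoc4)[C@@H](Cc4ccccc4)C3)cc2c1`, gives 63600 nM in this assay, a higher number beyond the scatter. Compound 3, `COc1ccc2[nH]c(C(=O)N3CC(=O)N(Cc4ccccc4)[C@@H](CN4CC5CCCC5C4)C3)cc2c1`, has the same atoms as compound 1 joined differently: a group of 8 heavy atoms (7 carbon, 1 nitrogen; one five-membered non-aromatic ring of carbon only, one five-membered non-aromatic ring with 1 hetero atom) in place of a group of 8 heavy atoms (7 carbon, 1 nitrogen; one three-membered non-aromatic ring of carbon only, one six-membered non-aromatic ring with 1 hetero atom), on a saturated chain carbon bound to a saturated ring carbon. Within the data shown here, with no measured step of this kind available, the step of a 1.1-fold higher number from compound 1 to compound 3 (0.03 log units; within the scatter) is expected to stay within the scatter, in no clear direction. Compound 3 is therefore estimated at 30000 nM, within the range 12000 nM to 75000 nM.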

Compound 3, solubility: 20700 nM
For compound 3 the middle estimate is 1.4-fold (0.16 log units) above the measured one; the measured number falls inside the stated range.
By their numbers in this assay, from the lowest: compounds 3 and 1 (each within the scatter of the next); then compound 2.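

At this saturated chain carbon bound to a saturated ring carbon, joining the same atoms as two five-membered rings instead of a three-membered and a six-membered ring gives a 1.4-fold lower number from compound 1 to compound 3 (0.13 log units; within the scatter) in this assay. Among these compounds, this is the only measured step at this position, and it does not separate the two ring arrangements. No measurement offered here bears on this result. The compounds shown leave open whether a morpholine on this carbon, or a simple dimethylamine, would read differently from these two bicyclic amines.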